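This account rests on a few compounds, and the source may have more. Where it says the series, first, only, none or still open, it means among the compounds named here.

Working notes on the amide series. In a functional assay on HepG2 cells (Homo sapiens) for antiproliferative activity, read by CCK-8 assay, with a stated time of 72 h (on this read-out lower numbers stand for stronger inhibition and higher numbers for weaker inhibition), compound 1 `O=C(Nc1cccc(-c2oc3cc(-c4ccc(F)cc4)ccc3c(=O)c2O)c1)c1ccc(Cl)cc1` gives 11000 nM; compound 2 `COc1ccccc1C(=O)Nc1cccc(-c2oc3cc(-c4ccc(F)cc4)ccc3c(=O)c2O)c1` gives 14500 nM; compound 3 `Cc1ccccc1C(=O)Nc1cccc(-c2oc3cc(-c4ccc(F)cc4)ccc3c(=O)c2O)c1` gives 19400 nM. Compound 3 stands at the highest of the three numbers, but every step connecting it to the others lies within the scatter: a 1.8-fold higher number from compound 1 to compound 3 (0.25 log units; within the scatter) and a 1.3-fold higher number from compound 2 to compound 3 (0.13 log units; within the scatter). The remaining pair also sits within the scatter, a 1.3-fold higher number from compound 1 to compound 2 (0.12 log units; within the scatter).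

Compound 4 `Cc1cccc(C(=O)Nc2cccc(-c3oc4cc(-c5ccc(F)cc5)ccc4c(=O)c3O)c2)c1` differs from compound 3 by 3-methylphenyl in place of 2-methylphenyl on a carbonyl carbon. For the measured compounds named here, the steps that bear on this change are those in which the aryl group on the carbonyl carbon was varied: 4-chlorophenyl to 2-methylphenyl and 2-methoxyphenyl to 2-methylphenyl, both within the scatter in this assay. The variations seen so far at this position have not moved the number beyond the scatter, so the expectation for compound 4 in this assay is a step of a 1.2-fold lower number from compound 3 to compound 4 (0.08 log units; within the scatter), that is, no change beyond the scatter. Compound 4 is therefore estimated at 16000 nM, with a range from 8000 nM to 32000 nM.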

Compound 4, half-maximal inhibitory concentration: 13500 nM
Estimate against measurement, compound 4: 1.2-fold (0.07 log units) above; low and high end bracket the measured number.
By their numbers in this assay, from the lowest: compounds 1, 4, 2 and 3 (each within the scatter of the next).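

The placement of the methyl group can now be judged apart from any change in atoms: in this assay, 3-methylphenyl in place of 2-methylphenyl on a carbonyl carbon, with the same atoms joined differently, gives a step within the scatter (a 1.4-fold lower number from compound 3 to compound 4 (0.16 log units; within the scatter)). Compound 4 also stays within the scatter of the other two aryl amides (a 1.1-fold lower number from compound 2 to compound 4 (0.03 log units; within the scatter); a 1.2-fold higher number from compound 1 to compound 4 (0.09 log units; within the scatter)), so none of the four aryl groups at this position is separated from the others. Nothing available gives a cause for these small differences.

As far as these compounds go, only aryl groups appear on this carbonyl carbon, so the effect of a longer alkyl chain or a group carrying an amine or a carboxylic acid remains open. Also open, from the compounds shown here alone, is whether any change at this position can move the number in this assay beyond the scatter.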